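The compounds below may be only part of what the source reports. "The series", "measured", "known", "first", "only" and "open" are said of these compounds alone.

Measured in a functional assay on HepG2 cells (Homo sapiens) for cytotoxicity, read by sulforhodamine B assay, with a stated time of 48 h; on this read-out lower numbers stand for stronger inhibition and higher numbers for weaker inhibition:
- compound 1 `COc1ccc(/C=C/C(=O)c2ccc(N)c(-c3ccc(F)cc3)c2)cc1O`: "not determined" (no result reported)
- compound 2 `O=C(/C=C/c1ccc(Br)cc1)c1cccc(-c2cccc(F)c2)c1`: 9920 nM
- compound 3 `COc1ccc(-c2cc(C(=O)/C=C/c3cc(OC)c(OC)c(OC)c3)ccc2N)cc1OC`: 2680 nM

Only two of these compounds have a number. Compound 2, at 9920 nM, holds the higher one, and so the weaker inhibition. Compound 3 gives 2680 nM, a gap beyond the usual scatter of repeated measurements.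

The next compound to be tested is compound 4 `COc1ccc(/C=C/C(=O)c2cccc(-c3cccc(F)c3)c2)cc1`. It differs from compound 2 by a single change: methoxy in place of bromo on an aromatic carbon. In other words, methoxy stands in place of bromo on an aromatic carbon, turning a 4-bromophenyl into a 4-methoxyphenyl.

For the measured compounds named here, no measured pair shows this change alone. Compound 3 also carries methoxy groups, but it differs from compound 2 in several other places, so compound 3 at 2680 nM offers only a loose guide. In this assay, a small shift towards a lower number is therefore expected, with nothing beyond the scatter. The estimated change is a 1.3-fold lower number from compound 2 to compound 4 (0.12 log units; within the scatter). For compound 4 the estimated value is 7500 nM, with an expected range of 2800 nM to 20000 nM.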

Compound 4, half-maximal inhibitory concentration: 1720 nM
For compound 4 the middle estimate is 4.4-fold (0.64 log units) above the measured one, and the stated range ends above it.
By their numbers in this assay, from the lowest: compounds 4 and 3 (each within the scatter of the next); then compound 2.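

In this assay, for the compounds shown here, methoxy in place of bromo on an aromatic carbon, para to a large group, gives a 5.8-fold lower number from compound 2 to compound 4 (0.76 log units; beyond the scatter), the first single change that can be read on its own. It shows that the number at this position depends on the group placed there, and that this swap moves the number by more than repeated measurements would. Compound 3 differs from compound 2 in several places at once, so the earlier compounds could not isolate this change, and no measurement shown here explains why the number falls.

Going by these compounds, with only bromo and methoxy compared here, it remains open where a chlorine, an ethoxy or a dimethylamino group would fall at this position. Also open, on these data alone, is whether the same swap gives a similar step on a core that carries an amine, as the core of compound 3 does.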